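Swapping Chloro for Hydroxymethyl on the Triazole Ring

This account rests on a few compounds, and the source may have more. Where it says the series, first, only, none or still open, it means among the compounds named here.

Compound 1, `CC(C)(C)OC(=O)c1cn(C[C@H]2CN(c3ccc(C4=CCS(=O)(=O)CC4)c(F)c3)C(=O)O2)nn1`, gives 3500 nM in an assay for binding affinity to Amine oxidase [flavin-containing] A (Homo sapiens); a lower number here means a stronger inhibitor, a higher number a weaker inhibitor.
Compound 2, `Cc1cn(C[C@H]2CN(c3ccc(C4=CCS(=O)(=O)CC4)c(F)c3)C(=O)O2)nn1`, gives 25000 nM in this assay.
Compound 3, `O=C1O[C@@H](Cn2cc(Cl)nn2)CN1c1ccc(C2=CCS(=O)(=O)CC2)c(F)c1`, gives 3000 nM in this assay.

Compound 3 stands with compound 1 at the low end of the three numbers; their gap is within the scatter, a 1.2-fold lower number from compound 1 to compound 3 (0.07 log units; within the scatter). Only compound 2 sits clearly apart, with an 8.3-fold lower number from compound 2 to compound 3 (0.92 log units; beyond the scatter) and a 7.1-fold higher number from compound 1 to compound 2 (0.85 log units; beyond the scatter). Compound 4, `O=C1O[C@@H](Cn2cc(CO)nn2)CN1c1ccc(C2=CCS(=O)(=O)CC2)c(F)c1`, differs from compound 3 by hydroxymethyl in place of chloro on an aromatic carbon. For the measured compounds named here, none of the measured steps swaps chloro for hydroxymethyl, so none bears directly on it. Going by the values given here, the only guide is that methyl at this position, in compound 2, gave a weaker result than chloro or tert-butoxycarbonyl, while those two groups were alike. On that thin basis, compound 4 is expected to give a somewhat higher number than compound 3, a step of a 2.7-fold higher number from compound 3 to compound 4 (0.43 log units; beyond the scatter), with wide uncertainty. The estimate for compound 4 is 8000 nM, with a range from 2000 nM to 30000 nM.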

Compound 4, inhibition constant: 47000 nM
For compound 4 the middle estimate is 5.9-fold (0.77 log units) below the measured one; the measured number lies above the stated range.
By their numbers in this assay, from the lowest: compounds 3 and 1 (each within the scatter of the next); then compounds 2 and 4 (each within the scatter of the next).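

In this assay, hydroxymethyl at this position separates sharply from chloro (a 16-fold higher number from compound 3 to compound 4 (1.19 log units; beyond the scatter)) and from tert-butoxycarbonyl (a 13-fold higher number from compound 1 to compound 4 (1.13 log units; beyond the scatter)), so the weaker result seen with methyl is not unique to that group. Hydroxymethyl and methyl cannot be told apart (a 1.9-fold higher number from compound 2 to compound 4 (0.27 log units; within the scatter)), which leaves the four compounds in two pairs: compounds 1 and 3 at the low end, and compounds 2 and 4 at the high end. Adding hydroxy to the methyl group, and with it a hydrogen-bond donor and acceptor, therefore produced no change beyond the scatter.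

Nothing shown here explains why the groups divide in this way. As far as these compounds go, it also remains open which pair an amine, a carboxylic acid or a longer chain at this position would join.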